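A few compounds are considered here, and "the series" means these few. Any claim that something is new, unique, unknown or untested is made for them only; others in the source may bear on it.

Compound 1 `CC(C)(C)c1ccc(NC(=O)CCl)cc1`, in a functional assay on M21 cells (Homo sapiens) for antiproliferative activity, with a stated time of 48 h; on this read-out lower numbers stand for stronger inhibition and higher numbers for weaker inhibition: 5400 nM
Compound 2 `CCCCC(OC)c1cccc(NC(=O)CCl)c1`, in this assay: 6900 nM
Compound 3 `CC(C)(C)c1ccc(CNC(=O)CCCl)cc1`, in this assay: a limit, > 100000 nM

Three compounds have numbers in this assay, and only two of them are true values. For compound 3 the assay reports a limit rather than a number, the one described by the limit of > 100000 nM in this assay, at which 1 of the 3 values shown sits. Compound 2 and compound 1 sit within the usual scatter of each other, so the two cannot be placed one ahead of the other on what has been measured; compound 2 is simply one of two near-identical values, with the third entry being a limit.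

Compound 4 `C=CC(=O)Nc1cccc(C(CCCC)OC)c1` has not yet been measured. It differs from compound 2 in one place: vinyl in place of chloromethyl on a carbonyl carbon. Among the measured compounds shown here, no measured pair of compounds shows this change, so its effect in this assay is not known from the data at hand and can only be anticipated.

For compound 4 the step of a 2.2-fold higher number from compound 2 to compound 4 (0.34 log units; beyond the scatter) is expected, a move towards weaker inhibition that may reach beyond the scatter. Compound 4 is therefore estimated at 15000 nM, with a range from 4000 nM to 60000 nM, and some chance that the assay returns only a limit.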

Compound 4, half-maximal inhibitory concentration: 48000 nM
For compound 4 the middle estimate is 3.2-fold (0.51 log units) below the measured one; low and high end bracket the measured number.
By their numbers in this assay, from the lowest: compounds 1 and 2 (each within the scatter of the next); then compound 4. At a limit, above all of these: compound 3.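

Among the compounds shown here, the change of vinyl in place of chloromethyl on a carbonyl carbon, whose other neighbour is an amide-type nitrogen, gives the only step that can be read at this position: in this assay it produces a 7.0-fold higher number from compound 2 to compound 4 (0.84 log units; beyond the scatter) on an otherwise unchanged structure. This shows that the position is not indifferent to the group it carries, as chloromethyl and vinyl have the same heavy-atom count yet are not interchangeable here, with chloromethyl giving the lower number. Nothing measured in this set accounts for the size of the step.

This single pair leaves open whether the same change would give a step of similar size on the core of compound 1, which also carries chloromethyl at this place. It also leaves open how other groups on this carbonyl carbon would compare, such as plain methyl, bromomethyl or a longer chain ending in chlorine, and so whether the chlorine itself or the whole group sets the number.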